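The source may hold more compounds than are shown below. What is called first, only, known or untested is meant among the compounds shown, and "the series" means these compounds.

Measured compounds and their values in a functional assay on Hs-578T cells (Homo sapiens) for inhibition, read by sulforhodamine B assay, with a stated time of 48 h; on this read-out lower numbers stand for stronger inhibition of growth and higher numbers for weaker inhibition of growth:
compound 1 `COc1cc(-c2cc(/C=C/C(=O)c3ccc(N)cc3)[nH]n2)cc(OC)c1OC` gives 4330 nM
compound 2 `COc1ccc(-c2cc(/C=C/C(=O)c3ccc(OC)c(OC)c3)[nH]n2)cc1` gives 3380 nM
compound 3 `COc1cc(-c2cc(/C=C/C(=O)c3ccc(Cl)c(Cl)c3)[nH]n2)cc(OC)c1OC` gives 16600 nM

These three compounds share one core and differ in the groups hung on its two ends. Compound 1 stands second highest of the three numbers; its nearest neighbour is compound 2, whose number lies within the scatter of repeated measurements, and its furthest is compound 3, reached by a 3.8-fold higher number from compound 1 to compound 3 (0.58 log units; beyond the scatter), a modest step beyond the scatter.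

The next compound, compound 4 `COc1ccc(-c2cc(/C=C/C(=O)c3ccc(N)cc3)[nH]n2)cc1OC`, keeps the 4-aminophenyl on the carbonyl carbon and changes the other ring: hydrogen in place of methoxy on an aromatic carbon. Among the measured compounds shown here, none of the measured steps touches this position, since the only step on record, from compound 1 to compound 3, alters the group on the carbonyl carbon instead. Compound 2 carries fewer methoxy groups on that ring, but it also differs on the carbonyl side, so its value gives no isolated reading of this change. With nothing to point either way, the expectation for compound 4 is a step no larger than the scatter, a 1.0-fold higher number from compound 1 to compound 4 (0.02 log units; within the scatter), and an estimated value of 4500 nM, within a range of 1500 nM to 14000 nM.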

Compound 4, concentration for 50% growth inhibition: 6570 nM
Beside the measured number, compound 4's estimate is 1.5-fold (0.16 log units) below it; measured number inside the range.
By their numbers in this assay, from the lowest: compounds 2, 1 and 4 (each within the scatter of the next); then compound 3.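

Among the compounds shown here, this is the first direct reading of the methoxy-bearing ring, and in this assay replacing one methoxy with hydrogen gives a 1.5-fold higher number from compound 1 to compound 4 (0.18 log units; within the scatter). With 4-aminophenyl held on the carbonyl carbon, this position therefore tolerates the loss of that methoxy without a change beyond the scatter, whereas the group on the carbonyl carbon has given a step beyond the scatter, a 3.8-fold higher number from compound 1 to compound 3 (0.58 log units; beyond the scatter). Nothing measured here offers an explanation for this result.

Going by these compounds, whether a hydroxy group, a fluorine atom or an ethoxy group at this position would read the same remains open. So does whether hydrogen in place of methoxy would give a similar step with 3,4-dichlorophenyl on the carbonyl carbon.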